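Bromo to methyl swap: cytotoxicity notes before compound 4

The source may hold more compounds than are shown below. What is called first, only, known or untested is meant among the compounds shown, and "the series" means these compounds.

Compound 1 `FC(F)(F)c1ccc(NCc2cn(-c3ccccc3)nc2-c2ccc(Br)cc2)cc1` is the reference. In an ADME assay on BHK-21 cells (Mesocricetus auratus) for cytotoxicity, read by MTT assay, with a stated time of 72 h (on this read-out lower numbers stand for higher toxicity in this test and higher numbers for lower toxicity in this test), compound 1 gives 20000 nM. Compound 2 `Cc1ccc(-c2nn(-c3ccccc3)cc2CNc2ccc(C(F)(F)F)cc2)cc1` differs from it by methyl in place of bromo on an aromatic carbon; in this assay compound 2 gives 88000 nM, a step of a 4.4-fold higher number from compound 1 to compound 2 (0.64 log units; beyond the scatter). Compound 3 `Brc1ccc(NCc2cn(-c3ccccc3)nc2-c2ccc(Br)cc2)cc1` differs from compound 1 by bromo in place of trifluoromethyl on an aromatic carbon. Compound 3 in this assay gives only a limit, > 100000 nM, in line with the limit of > 100000 nM in this assay, at which 1 of the 3 values shown sits. The step of an at least 5.0-fold higher number from compound 1 to compound 3 (0.69 log units; beyond the scatter) is thus a bound rather than a number. Compound 4 `Cc1ccc(NCc2cn(-c3ccccc3)nc2-c2ccc(Br)cc2)cc1` is not yet measured; it differs from compound 3 by methyl in place of bromo on an aromatic carbon, the same change as from compound 1 to compound 2, with the same surroundings at the place. From compound 3 to compound 4 the step is expected to be a step that the limit leaves unreadable from compound 3 to compound 4, resting on a 4.4-fold higher number from compound 1 to compound 2 (0.64 log units; beyond the scatter) applied to a start that is itself a limit. Compound 4 is therefore expected to give 250000 nM in this assay, most likely reported again only as a limit, within 90000 nM to 700000 nM.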

Compound 4, half-maximal cytotoxic concentration: > 100000 nM
Compound 4: only a limit was reported (the forecaster's own chance of this, stated with the estimate: 80%); the middle value lies beyond the limit too.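

In this assay compound 4 gives > 100000 nM, which is a limit and not a number. The change of methyl in place of bromo, here (4-bromophenyl)amino to (4-methylphenyl)amino, cannot be read between compound 3 and compound 4, because both values are limits: the limit of > 100000 nM in this assay, at which 2 of the 4 values shown sit. The rise seen in a 4.4-fold higher number from compound 1 to compound 2 (0.64 log units; beyond the scatter) is thus neither confirmed nor contradicted on this second pair, and the only readable result is a bound, an at least 5.0-fold higher number from compound 1 to compound 4 (0.69 log units; beyond the scatter), for methyl in place of trifluoromethyl.

Going by these compounds, how far compound 3 and compound 4 actually lie apart stays open. Also open, on these data alone, is whether a carboxylic acid or an amine in place of the methyl in compound 4 would give a measurable value in this assay.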